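This account rests on a few compounds, and the source may have more. Where it says the series, first, only, none or still open, it means among the compounds named here.

Values in a functional assay on HeLa cells (Homo sapiens) for antiproliferative activity, with a stated time of 48 h; a higher number here means a weaker inhibitor, a lower number a stronger inhibitor:
Compound 1, `C=C(Br)C(=O)Nc1ccc(/C=C/C(=O)c2ccccc2)cc1`: 3900 nM
Compound 2, `C=C(Br)C(=O)Nc1ccc(/C=C/C(=O)c2cccc(OC)c2)cc1`: 700 nM
Compound 3, `C=C(Br)C(=O)Nc1ccc(C(=O)/C=C/c2ccccc2OC)cc1`: 1300 nM

From compound 1 to compound 2 the change is methoxy in place of hydrogen on an aromatic carbon; this gave a 5.6-fold lower number from compound 1 to compound 2 (0.75 log units; beyond the scatter). Compound 3 sits on another core; the difference between the core of compound 1 and the core of compound 3 is not broken down here. Compound 3 and compound 2 lie within the scatter of each other, while compound 3 sits beyond the scatter from compound 1.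

Compound 4, `C=C(Br)C(=O)Nc1ccc(C(=O)/C=C/c2ccc(OC)cc2OC)cc1`, awaits measurement in this assay. It differs from compound 3 by methoxy in place of hydrogen on an aromatic carbon. This is the same kind of change as from compound 1 to compound 2, not the same: there the entering group stood meta to a large group, here it stands meta to a methoxy group and para to a large group. The surroundings therefore differ, and the expected step is set smaller than the earlier one, at a 2.6-fold lower number from compound 3 to compound 4 (0.41 log units; beyond the scatter), resting on compound 3 at 1300 nM and on a 5.6-fold lower number from compound 1 to compound 2 (0.75 log units; beyond the scatter). Compound 4 is thus expected near 500 nM, likely between 150 nM and 1500 nM.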

Compound 4, half-maximal inhibitory concentration: 1100 nM
Estimate against measurement, compound 4: 2.2-fold (0.34 log units) below, and the stated range covers the measured number.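

In this assay, methoxy in place of hydrogen on an aromatic carbon, here meta to a methoxy group and para to a large group, gives a 1.2-fold lower number from compound 3 to compound 4 (0.07 log units; within the scatter), so this step on the core of compound 3 shows no readable effect. The change therefore does not carry over in size from the core of compound 1 to the core of compound 3: the same change on two cores in this assay, a 5.6-fold lower number (0.75 log units; beyond the scatter) from compound 1 to compound 2 and a 1.2-fold lower number (0.07 log units; within the scatter) from compound 3 to compound 4, 4.7-fold (0.67 log units) apart, beyond the scatter of two such steps

This does not show that the core alone sets the size of the step, since the two steps also differ in the surroundings of the entering methoxy, and a single pair on each core cannot separate these two differences or give a cause.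

On these data alone, it remains open whether the step on the core of compound 3 depends on the methoxy group already on that ring, and whether a second methoxy group on the core of compound 1 would also leave the number within the scatter. As far as these compounds go, it is equally open how an amine or a carboxylic acid in the place of the entering methoxy would read on either core.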